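The source may report more compounds than this note shows. Statements on the series, on what has been measured and on what is new or still open speak of the compounds shown alone.

Of the compounds shown here, two have been measured so far. Compound 1 `O=C(O)CCCSCCN1C(=O)CC[C@@H]1/C=C/[C@@H](O)Cc1cccc(OCc2ccncc2)c1` in an assay on CHO cells for displacement of a labelled ligand from prostaglandin E2 receptor EP3 subtype (Mus musculus), read by scintillation counting, with a stated time of 60 min (on this read-out lower numbers stand for stronger inhibition and higher numbers for weaker inhibition), returns only a limit, > 10000 nM, and not a number. Among the compounds with values here, compound 2 `O=C(O)c1csc(SCCN2C(=O)CC[C@@H]2/C=C/[C@@H](O)Cc2cccc(-c3ccccc3)c2)n1` gives 4300 nM in this assay, and that is the only numerical value on hand, the other result being (the limit of > 10000 nM in this assay, at which 1 of the 2 values shown sits). Compound 3 `Cc1cc(C)c2oc(-c3cccc(C[C@H](O)/C=C/[C@H]4CCC(=O)N4CCSc4nc(C(=O)O)cs4)c3)nc2c1` has not yet been measured. It differs from compound 2 in one place: 5,7-dimethyl-1,3-benzoxazol-2-yl in place of phenyl on an aromatic carbon. Within the data shown here, with no measured step between two numbers available, the size of the change cannot be read from the data, and any expectation rests on the single value of compound 2 and on the nature of the replacement. The group that enters is the larger of the two and carries hydrogen-bond acceptors where the phenyl has none, so a moderate gain in binding is expected, estimated as a 2.9-fold lower number from compound 2 to compound 3 (0.46 log units; beyond the scatter). Compound 3 is therefore expected to give about 1500 nM in this assay, with a range from 300 nM to 8000 nM.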

Compound 3, inhibition constant: > 10000 nM
Compound 3: a limit, no number (the forecaster's own chance of this, stated with the estimate: 15%); middle value at least 6.6-fold (0.82 log units) from the limit.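

Placing 5,7-dimethyl-1,3-benzoxazol-2-yl in place of phenyl on this aromatic carbon gives an at least 2.3-fold higher number from compound 2 to compound 3 (0.36 log units; beyond the scatter) in this assay. Within the data shown here, this is the first comparison that isolates one change, and it shows that the position is not indifferent to what it carries: the larger group, with its hydrogen-bond acceptors where phenyl has none, goes with weaker binding and not stronger. The result for compound 3 is a limit and not a number, so the step gives only a minimum, and the limit of the assay now holds most of the results: the limit of > 10000 nM in this assay, at which 2 of the 3 values shown sit.

The compounds shown do not separate the contribution of the two methyl groups from that of the five-membered ring, which an unsubstituted 1,3-benzoxazol-2-yl group on the same carbon would address. They also leave open whether a smaller change at this position, such as a pyridine ring or a phenyl ring carrying a single fluorine atom, would keep the binding of compound 2 or improve on it.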